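Aryl replacement of ethyl on the ring amine: compound 4

The compounds below may be only part of what the source reports. "The series", "measured", "known", "first", "only" and "open" are said of these compounds alone.

Compound 1 `CCCN1CCC(c2noc(COc3ccc(/C=C/C(=O)NO)cc3)n2)CC1` gives 69% in an assay on isolated protein for inhibition of protein deacetylase HDAC6 (Homo sapiens), read by fluorescence, with a stated time of 1 h, tested at 100 nM; on this read-out lower numbers stand for less inhibition and higher numbers for more inhibition at the one concentration tested (going by the name of the read-out). Of the three measured compounds it carries the smallest number, yet each gap to the other two is within the usual scatter. Compound 2 `Cc1ccc(CN2CCC(c3noc(COc4ccc(/C=C/C(=O)NO)cc4)n3)CC2)cc1` gives 76%, and compound 3 `O=C(/C=C/c1ccc(OCc2nc(C3CCN(Cc4cccc(F)c4)CC3)no2)cc1)NO` gives 73%. The measured steps are all small: a number 7 percentage points higher from compound 1 to compound 2 (within the scatter), a number 4 percentage points higher from compound 1 to compound 3 (within the scatter), and a number 3 percentage points lower from compound 2 to compound 3 (within the scatter). In this set, putting an aromatic ring in place of ethyl on the saturated chain carbon bound to the amine nitrogen in the ring has not moved the read-out beyond the scatter, whether the ring carries a methyl or a fluorine.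

Compound 4 `O=C(/C=C/c1ccc(OCc2nc(C3CCN(Cc4ccc(F)cc4)CC3)no2)cc1)NO` is the next member. Relative to compound 1 the change is 4-fluorophenyl in place of ethyl on a saturated chain carbon bound to an amine nitrogen in a ring. The steps from compound 1 to compound 2 and from compound 1 to compound 3 bear directly on it, both being single aryl-for-ethyl changes at the same place, and both stayed within the scatter. No step beyond the scatter is therefore expected in this assay, and any drift should be upward by a few points at most.

Compound 4 is estimated at 73%, with a range from 61% to 85%. The expected step is a number 4 percentage points higher from compound 1 to compound 4 (within the scatter).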

Compound 4, a percentage reported as inhibition, at one concentration (the size of the read-out at that concentration, not a potency): 75%
Compound 4: middle estimate off by 2 percentage points, on the low side; measured number inside the range.
By their numbers in this assay, from the lowest: compounds 1, 3, 4 and 2 (each within the scatter of the next).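

In this assay, 4-fluorophenyl in place of ethyl on the saturated chain carbon bound to the amine nitrogen in the ring stays within the scatter (a number 6 percentage points higher from compound 1 to compound 4 (within the scatter)), so all three aryl groups shown at this place now read alike against ethyl. Two comparisons not available before separate changes on the aromatic ring itself: 4-fluorophenyl in place of 3-fluorophenyl (a number 2 percentage points higher from compound 3 to compound 4 (within the scatter)) and fluoro in place of methyl on an aromatic carbon (a number 1 percentage points lower from compound 2 to compound 4 (within the scatter)) both leave the read-out within the scatter, so neither change distinguishes these compounds in this assay. No measured evidence bears on why these groups read alike.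

From the compounds shown here alone, whether a carboxylic acid or an amine on the aromatic ring, or a longer chain in place of 4-fluorobenzyl, would produce a step beyond the scatter remains open. Going by these compounds, because this assay reports a single concentration rather than a potency, any difference among compounds 1 to 4 that this one reading does not resolve also remains open.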